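The compounds below may be only part of what the source reports. "The series", "measured", "known", "first", "only" and "open" are said of these compounds alone.

Values in a functional assay on HeLa cells (Homo sapiens) for inhibition, read by CCK-8 assay, with a stated time of 48 h; a higher number here means a weaker inhibitor, a lower number a stronger inhibitor:
- compound 1 `O=C(NCCNS(=O)(=O)c1ccc(-c2ccccc2O[C@H]2CC[C@@H](O)CC2)s1)Nc1ccc([N+](=O)[O-])cc1` gives > 20000 nM, a limit
- compound 2 `O=[N+]([O-])c1ccc(NC(=S)NCCNS(=O)(=O)c2ccc(-c3ccccc3O[C@H]3CC[C@@H](O)CC3)s2)cc1` gives > 20000 nM, a limit
- compound 3 `COc1ccc(NC(=O)NCCNS(=O)(=O)c2sccc2-c2ccc(C)cc2Oc2ccc(O)c(O)c2)cc1` gives > 20000 nM, a limit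

Compound 1 has only a limit, so its standing cannot be ranked, and the series shows (the limit of > 20000 nM in this assay, at which 3 of the 3 values shown sit). Compound 4 `O=C(NCCNS(=O)(=O)c1ccc(-c2ccccc2Oc2ccc([N+](=O)[O-])c([N+](=O)[O-])c2)s1)Nc1ccc([N+](=O)[O-])cc1` carries 3,4-dinitrophenyl in place of 4-hydroxycyclohexyl on an oxygen on an aromatic ring. Among the measured compounds shown here, the one measured step that the two limits leave unreadable from compound 1 to compound 2 lies on an amine nitrogen, not at this place, and has no readable size. Compound 3 also has an aromatic ring on such an oxygen, and its > 20000 nM is a limit. In this assay the estimated step of a number no higher from compound 1 to compound 4 (the limit leaves the size open) is none beyond the scatter, with no direction expected. The estimate for compound 4 is 20000 nM, with an expected range from 6000 nM to 40000 nM.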

Compound 4, half-maximal inhibitory concentration: > 20000 nM
Compound 4: only a limit was reported; the forecaster's own chance of this, stated with the estimate: 60%; the middle value lies on the limit itself.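

No new step can be read between compound 1 and compound 4, as both are reported only as limits. The compounds shown leave open whether any of these changes alters inhibition, with every value at one limit: the limit of > 20000 nM in this assay, at which 4 of the 4 values shown sit.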